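The compounds below may be only part of what the source reports. "The series", "measured", "known", "first", "only" and "open" are said of these compounds alone.

Measured compounds and their values in an in vitro assay on cells for displacement of a labelled ligand from thyroid hormone receptor beta (Homo sapiens), with a stated time of 48 h; a higher number here means a weaker inhibitor, a lower number a stronger inhibitor:

Compound 1 `Cc1cc(NC(=O)CC(=O)O)c2c(c1Oc1ccc(O)c(C(O)Cc3ccccc3)c1)CCC2` gives 124 nM.
Compound 2 `Cc1cc(NC(=O)CC(=O)O)c2c(c1Oc1ccc(O)c(CCc3ccc(F)cc3F)c1)CCC2` gives 12 nM.
Compound 3 `Cc1cc(NC(=O)CC(=O)O)c2c(c1Oc1ccc(O)c(CCc3cccc(Cl)c3)c1)CCC2` gives 41 nM.

Among these three, compound 3 stands in the middle: the step of a 3.0-fold lower number from compound 1 to compound 3 (0.48 log units; beyond the scatter) sets it apart from compound 1, and the step of a 3.4-fold higher number from compound 2 to compound 3 (0.53 log units; beyond the scatter) sets it apart from compound 2, both beyond the scatter.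

Compound 4 `Cc1cc(NC(=O)CC(=O)O)c2c(c1Oc1ccc(O)c(CCc3cccc(O)c3)c1)CCC2` is not yet measured. It differs from compound 3 by hydroxy in place of chloro on an aromatic carbon. For the measured compounds named here, no measured pair swaps a chloro for a hydroxy, so the closest guide is the step of a 3.4-fold higher number from compound 2 to compound 3 (0.53 log units; beyond the scatter), which shows that changing the substituents on that distal ring shifts this assay by a modest amount, and the larger step of a 10-fold lower number from compound 1 to compound 2 (1.01 log units; beyond the scatter), which shows that changes around this part of the molecule can matter more. A modest change in either direction is therefore expected, most likely a somewhat higher number.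

Compound 4 is estimated at 70 nM, within a range from 20 nM to 250 nM, meaning an expected step of a 1.7-fold higher number from compound 3 to compound 4 (0.23 log units; within the scatter).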

Compound 4, inhibition constant: 81.3 nM
Estimate against measurement, compound 4: 1.2-fold (0.06 log units) below; the measured number falls inside the stated range.
By their numbers in this assay, from the lowest: compound 2; then compounds 3, 4 and 1 (each within the scatter of the next, the first and the last beyond it).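

In this assay, the step of a 2.0-fold higher number from compound 3 to compound 4 (0.30 log units; within the scatter) shows that this position on the aromatic ring takes hydroxy, which brings a hydrogen-bond donor and acceptor that chloro lacks, with no change that can be told from the scatter. Compound 2 still stands clearly apart from this new compound through the step of a 6.8-fold higher number from compound 2 to compound 4 (0.83 log units; beyond the scatter) and the 2-(3-hydroxyphenyl)ethyl group cannot be told from the 1-hydroxy-2-phenylethyl group through the step of a 1.5-fold lower number from compound 1 to compound 4 (0.18 log units; within the scatter) in this assay.

The compounds shown leave open how an amine or a carboxylic acid would behave in place of chloro at this position. They also leave open whether one fluoro alone, as in a 4-fluorophenyl group, would match the 2,4-difluorophenyl group of compound 2.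

Nothing else given here bears on the reason for these numbers.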